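Changing the Aryl Group on a Shared Core

The source may hold more compounds than are shown below. What is called first, only, known or untested is meant among the compounds shown, and "the series" means these compounds.

Measured in a functional assay on MCF7 cells (Homo sapiens) for cytotoxicity, read by MTT assay, with a stated time of 48 h; on this read-out lower numbers stand for stronger inhibition and higher numbers for weaker inhibition:
- Compound 1 `COc1ccc(/C=C2/S/C(=N/c3ccccc3)N(Cc3ccncc3)C2=O)cc1`: 31500 nM
- Compound 2 `COc1cc(/C=C2/S/C(=N/c3ccccc3)N(Cc3ccncc3)C2=O)ccc1O`: 28000 nM

Within the data shown here, compound 2 stands level with the only other measured compound. Among the measured compounds shown here, the single measured step, at the same place as the next change, is a 1.1-fold lower number from compound 1 to compound 2 (0.05 log units; within the scatter), and it stays within the scatter. Compound 3 `O=C1/C(=C\c2cccc(Cl)c2)S/C(=N/c2ccccc2)N1Cc1ccncc1` differs from compound 2 by one change: 3-chlorophenyl in place of 4-hydroxy-3-methoxyphenyl on a double-bonded chain carbon bound to a double-bonded ring carbon. For the measured compounds named here, no measured compound carries 3-chlorophenyl, so this evidence is thin. In this assay, no shift beyond the scatter and no clear direction are expected, and the estimate is a 1.1-fold lower number from compound 2 to compound 3 (0.05 log units; within the scatter). Compound 3 is expected at 25000 nM, with an estimated range of 10000 nM to 60000 nM.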

Compound 3, half-maximal inhibitory concentration: 29800 nM
Beside the measured number, compound 3's estimate is 1.2-fold (0.08 log units) below it, and the stated range covers the measured number.
By their numbers in this assay, from the lowest: compounds 2, 3 and 1 (each within the scatter of the next).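

In this assay the larger swap, which takes away both oxygens and the hydrogen-bond donor and brings in chlorine, gives a 1.1-fold higher number from compound 2 to compound 3 (0.03 log units; within the scatter) and a 1.1-fold lower number from compound 1 to compound 3 (0.02 log units; within the scatter) and so stays within the scatter. So on a double-bonded chain carbon bound to a double-bonded ring carbon, even an aryl group with no hydrogen-bond donors or acceptors gives a number level with the two oxygen-bearing ones. Nothing available explains this lack of change.

Still open, as far as these compounds go, is whether an amine or a carboxylic acid on this aryl ring would move the number beyond the scatter. From the compounds shown here alone, a longer chain in place of the ring is equally open.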